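The compounds below may be only part of what the source reports. "The series", "measured", "known", "first", "only" and "open" are said of these compounds alone.

Compound 1 `O=C(O)CCC(=O)OCCOc1no[n+]([O-])c1S(=O)(=O)c1ccccc1`: > 10000 nM, a limit
Compound 2 `O=C(O)CCCC(=O)OCCOc1no[n+]([O-])c1S(=O)(=O)c1ccccc1`: 4000 nM
Compound 3 `O=C(O)CCC(=O)OCCCOc1no[n+]([O-])c1S(=O)(=O)c1ccccc1`: 6400 nM

Among the measured compounds shown here, in a functional assay on HepG2 cells (Homo sapiens) for antiproliferative activity, read by MTT assay, with a stated time of 72 h (on this read-out lower numbers stand for stronger inhibition and higher numbers for weaker inhibition), compound 2 holds one of only two true numbers, 4000 nM. The gap to the other is a 1.6-fold higher number from compound 2 to compound 3 (0.20 log units; within the scatter). The entry for compound 1 is a limit. Compound 4 `O=C(O)c1ccccc1C(=O)OCCOc1no[n+]([O-])c1S(=O)(=O)c1ccccc1` keeps the shared core and changes one group: 2-carboxyphenyl in place of 3-carboxypropyl on a carbonyl carbon. The closest measured evidence is an at least 2.5-fold lower number from compound 1 to compound 2 (0.39 log units; beyond the scatter), a change in this same group. On these data alone, no aromatic ring has been measured at that place, so the direction stays open. The expected step is small, a 1.3-fold higher number from compound 2 to compound 4 (0.10 log units; within the scatter), and is not expected to pass beyond the scatter. Compound 4 is estimated at 5000 nM, with an expected range from 1500 nM to 16000 nM.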

Compound 4, half-maximal inhibitory concentration: > 10000 nM
Compound 4: no number, only a limit; the forecaster's own chance of this, stated with the estimate: 30%; middle value at least 2.0-fold (0.30 log units) from the limit.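

Placing 2-carboxyphenyl instead of 3-carboxypropyl on this carbonyl carbon weakens the result in this assay: an at least 2.5-fold higher number from compound 2 to compound 4 (0.39 log units; beyond the scatter). Among the compounds shown here, this is the first aromatic ring measured at this place, and the step shows that the level of compound 2 is not kept with it. Compound 4 gives only a limit, > 10000 nM, and its step to compound 1 cannot be read.

The compounds shown leave open whether a cyclohexane ring carrying the carboxylic acid, or a longer chain, would keep that level on this carbonyl carbon. On these data alone, whether the loss follows from the aromatic ring itself or from the larger group also stays open.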